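The source may report more compounds than this note shows. Statements on the series, on what has been measured and on what is new or still open speak of the compounds shown alone.

Three measured compounds share one core: compound 1 `COc1ccnc(Nc2cc3[nH]c(-c4cccc(C(F)(F)F)c4)nc3cn2)c1`, compound 2 `FC(F)(F)c1cccc(-c2nc3cnc(Nc4ccncn4)cc3[nH]2)c1` and compound 3 `FC(F)(F)c1cccc(-c2nc3cnc(Nc4cnccn4)cc3[nH]2)c1`. In a physicochemical assay for solubility, using the shake flask method, in phosphate buffer, measured as kinetic solubility, with a stated time of 20 h, at pH 6.5 (on this read-out higher numbers stand for higher solubility and lower numbers for lower solubility), compound 1 gives < 5000 nM, which is a limit of the assay and not a number. Compound 2 likewise gives < 5000 nM, again a limit. Compound 3 stands at < 5000 nM, once more only a limit. The steps a step that the two limits leave unreadable from compound 1 to compound 2, a step that the two limits leave unreadable from compound 1 to compound 3 and a step that the two limits leave unreadable from compound 2 to compound 3 therefore carry no readable size, since every value sits at the same bound (the limit of < 5000 nM in this assay, at which 3 of the 3 values shown sit). Compound 4 `FC(F)(F)c1cccc(-c2nc3cnc(Nc4cccnn4)cc3[nH]2)c1` is the next isomer: pyridazin-3-yl in place of pyrazin-2-yl on a nitrogen on an aromatic ring. Among the compounds with values here, no measured step reads a size for such a change, so nothing beyond another limit is expected in this assay; the expected step that the limit leaves unreadable from compound 3 to compound 4 is taken as flat. Compound 4 is estimated at 2000 nM, within 300 nM to 6000 nM, most likely reported again as a limit.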

Compound 4, solubility: < 5000 nM
Compound 4: only a limit was reported; the forecaster's own chance of this, stated with the estimate: 80%; the middle value lies beyond the limit too.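

No step among compound 1, compound 2, compound 3 and compound 4 can be read in this assay: the limit of < 5000 nM in this assay, at which 4 of the 4 values shown sit.

The compounds shown leave open whether pyridazin-3-yl, pyrazin-2-yl, pyrimidin-4-yl and 4-methoxypyridin-2-yl differ at all on this read-out.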